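Methyl added to the pyrazole of a chemokine receptor antagonist

The compounds below may be only part of what the source reports. "The series", "measured", "known", "first", "only" and "open" are said of these compounds alone.

Compound 2 `CCOc1ncc(-c2nc(C(F)(F)F)sc2N2CCN(C(=O)Cn3nccc3C)[C@H](C)C2)cn1`: 2 nM
Compound 1 `CCOc1ncc(-c2nc(C(F)(F)F)sc2N2CCN(C(=O)Cn3ccc4cnccc43)[C@H](C)C2)cn1`: 3.6 nM

Within the data shown here, in a functional assay on CHO-K1 cells for antagonist activity at C-X-C chemokine receptor type 3 (Homo sapiens), read by FLIPR, with a stated time of 10 min (a higher number here means a weaker inhibitor, a lower number a stronger inhibitor), compound 2 gives 2 nM, the lower of the two numbers, though compound 1 at 3.6 nM sits within the scatter of it, the only measured step being a 1.8-fold lower number from compound 1 to compound 2 (0.26 log units; within the scatter). Compound 3 `CCOc1ncc(-c2nc(C(F)(F)F)sc2N2CCN(C(=O)Cn3nc(C)cc3C)[C@H](C)C2)cn1` differs from compound 2 by methyl in place of hydrogen on an aromatic carbon. Among the measured compounds shown here, no measured step alters this ring in the same way, so the single step exchanging the whole heteroaryl group offers no direct guide. Compound 3 is therefore expected to stay near compound 2, with a step of a 1.3-fold higher number from compound 2 to compound 3 (0.10 log units; within the scatter) and an estimated 2.5 nM, between 1 nM and 8 nM.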

Compound 3, half-maximal inhibitory concentration: 2.3 nM
Estimate against measurement, compound 3: 1.1-fold (0.04 log units) above; the measured number falls inside the stated range.
By their numbers in this assay, from the lowest: compounds 2, 3 and 1 (each within the scatter of the next).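

In this assay the change from 5-methyl-1H-pyrazol-1-yl to 3,5-dimethyl-1H-pyrazol-1-yl gives a 1.2-fold higher number from compound 2 to compound 3 (0.06 log units; within the scatter) and thus shows that this aromatic carbon carries a methyl group with no step beyond the scatter. Replacing the two-ring group of compound 1 with the dimethyl pyrazole gives a 1.6-fold lower number from compound 1 to compound 3 (0.19 log units; within the scatter) and so also stays within the scatter. Nothing available bears on why these numbers stay so close.

The compounds shown leave open how an amine or a carboxylic acid at this carbon would read. They also leave open what hydrogen in place of the other pyrazole methyl would do.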